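The source may report more compounds than this note shows. Statements on the series, on what has been measured and on what is new or still open speak of the compounds shown alone.

Compound 2 `O=C1N(CCCCCCOc2ccc(C(F)(F)F)cc2)CCN1c1ccnc(Cl)c1` carries a trifluoromethyl group on its aromatic ring. In a functional assay on cells (Homo sapiens) for cytotoxicity (on this read-out lower numbers stand for higher toxicity in this test and higher numbers for lower toxicity in this test), compound 2 gives > 25000 nM, which is a limit of the assay and not a number. Its nearest neighbour, compound 1 `O=C1N(CCCCCCOc2ccc(Br)cc2)CCN1c1ccnc(Cl)c1`, bears a bromo on that aromatic carbon instead. In this assay compound 1 gives > 25000 nM, again a limit rather than a number. The step that the two limits leave unreadable from compound 1 to compound 2 therefore cannot be read, because of the limit of > 25000 nM in this assay, at which 2 of the 2 values shown sit. Compound 3 `CSc1ccc(OCCCCCCN2CCN(c3ccnc(Cl)c3)C2=O)cc1` differs from compound 2 by a single change: methylsulfanyl in place of trifluoromethyl on an aromatic carbon. Among the compounds with values here, only one measured step touches this aromatic carbon, and its size is hidden by the two limits, so nothing measured suggests that a change at this site carries the read-out out of the region where the assay stops counting. For compound 3 the step that the limit leaves unreadable from compound 2 to compound 3 is expected to be none beyond the scatter. Compound 3 is accordingly estimated at 35000 nM, with a range from 12000 nM to 100000 nM, and it is expected most likely to be reported once more only as a limit.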

Compound 3, half-maximal cytotoxic concentration: > 25000 nM
Compound 3: only a limit was reported; the forecaster's own chance of this, stated with the estimate: 80%; the middle value lies beyond the limit too.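

No step among compound 1, compound 2 and compound 3 can be read in this assay, because each of the three gives a limit of the assay and not a number: the limit of > 25000 nM in this assay, at which 3 of the 3 values shown sit.

The compounds shown leave open how far bromo, trifluoromethyl and methylsulfanyl on this aromatic carbon differ in this assay, and what change would bring the read-out to a countable value.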